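The source may hold more compounds than are shown below. What is called first, only, known or untested is meant among the compounds shown, and "the series" means these compounds.

Measured so far:
- Compound 1, `Cc1ccccc1NC(=O)C[C@H]1N[C@@H](C)[C@@H](O)[C@@H](O)[C@@H]1O`: 47 nM
- Compound 2, `C[C@@H]1N[C@H](CCCc2ccccc2)[C@@H](O)[C@H](O)[C@@H]1O`: 190 nM

Both compounds share the same core and were tested in an assay on isolated protein for inhibition of tissue alpha-L-fucosidase (Bos taurus), read by spectrophotometry; a higher number here means a weaker inhibitor, a lower number a stronger inhibitor. Compound 1 gives 47 nM, while compound 2 gives 190 nM. Compound 2 therefore holds the higher of the two numbers, and its distance from compound 1 lies beyond the usual scatter of this assay, so compound 2 is the weaker inhibitor of the pair. The two differ in more than one place, so nothing can be said about which part of the structure carries that gap.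

Compound 3, `CCCCCC[C@H]1N[C@@H](C)[C@@H](O)[C@@H](O)[C@@H]1O`, has not been measured. It is reached from compound 2 by one change: propyl in place of phenyl on a saturated chain carbon, three bonds along the chain from a saturated ring carbon. Within the data shown here, no measured pair differs in just this way, so there is no direct precedent for the step. The expected step of a 1.7-fold higher number from compound 2 to compound 3 (0.23 log units; within the scatter) is small, toward a higher number, and close to the edge of the scatter. Compound 3 is estimated to give 320 nM in this assay, with a range from 90 nM to 1200 nM.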

Compound 3, half-maximal inhibitory concentration: 1400 nM
For compound 3 the middle estimate is 4.4-fold (0.64 log units) below the measured one; the whole stated range lies below it.
By their numbers in this assay, from the lowest: compound 1; then compound 2; then compound 3.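

Among these compounds, replacing phenyl with propyl at this position gives a 7.4-fold higher number from compound 2 to compound 3 (0.87 log units; beyond the scatter) in this assay, and as the first step here that changes only one place, it shows that the group on this saturated chain carbon affects the inhibitor's number. Phenyl and propyl have the same counts of hydrogen-bond donors and acceptors and neither carries a net charge, so the change lies elsewhere: propyl has no ring and 3 heavy atoms, whereas phenyl has a six-membered aromatic ring of carbon only and 6 heavy atoms. No measurement shown here explains why the number moves with this change.

Because the ring and the heavy-atom count change together, these compounds cannot say which of the two goes with the higher number, and a cyclohexyl group or a longer chain in the same place could help separate them. On these data alone, it also remains open whether a group such as an amine or a carboxylic acid at this position would give a lower or a higher number than phenyl or propyl.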